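The compounds below may be only part of what the source reports. "The series", "measured", "known", "first", "only" and "open" are said of these compounds alone.

Of the compounds shown here, three built on one shared core have been tested in a functional assay on the whole organism (blood, strain Charles Foster/Wistar albino) with Rattus norvegicus as the target, with a stated time of 30 min, at a dose of 100 mg/kg by the oral route; on this read-out lower numbers stand for less inhibition and higher numbers for more inhibition at the one dose given (going by the name of the read-out). Compound 1 `CCCCN(C)CCCOc1cc(OC)ccc1-c1cc(-c2ccccc2)no1` gives 15%. Compound 2 `CCOC(=O)COc1cc(OC)ccc1-c1cc(-c2ccccc2)no1` gives 10.4%. Compound 3 `COc1ccc(-c2cc(-c3ccccc3)no2)c(O)c1` gives 9.8%, the lowest of the three numbers, yet the step of a number 5.2 percentage points lower from compound 1 to compound 3 (within the scatter) and the step of a number 0.6 percentage points lower from compound 2 to compound 3 (within the scatter) both lie within the scatter, so the three compounds cannot be ranked against each other on these figures.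

Compound 4 `CCN(CC)CC(O)COc1cc(OC)ccc1-c1cc(-c2ccccc2)no1` has not yet been measured. It differs from compound 3 in a single place: 3-(diethylamino)-2-hydroxypropyl in place of hydrogen on an oxygen on an aromatic ring. The measured steps that bear on this change are the two that also exchange the group on that same oxygen, a number 5.2 percentage points lower from compound 1 to compound 3 (within the scatter) and a number 0.6 percentage points lower from compound 2 to compound 3 (within the scatter), each of them small and within the scatter. On that basis, no step beyond the scatter is expected in this assay, and compound 4 is estimated at 12% with a range from 3% to 24%. The expected step is a number 2.2 percentage points higher from compound 3 to compound 4 (within the scatter).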

Compound 4, a percentage reported as inhibition, in the whole organism at one dose (the size of the read-out at that dose, not a potency): 13.8%
The estimate for compound 4 lay 1.8 percentage points below the measured number; the range from low to high includes it.
By their numbers in this assay, from the lowest: compounds 3, 2, 4 and 1 (each within the scatter of the next).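

In this assay, the step of a number 4 percentage points higher from compound 3 to compound 4 (within the scatter) shows that even a chain as large as 3-(diethylamino)-2-hydroxypropyl, placed on the oxygen on the aromatic ring where compound 3 carries only hydrogen, gives no change that can be told from scatter. Comparison with the other substituted compounds points the same way, with the step of a number 3.4 percentage points higher from compound 2 to compound 4 (within the scatter) against the ethoxycarbonyl chain and the step of a number 1.2 percentage points lower from compound 1 to compound 4 (within the scatter) against the butyl(methyl)amino chain, so a hydroxyl on the chain and a change of amine leave no readable mark here. No measurement offered here accounts for these results.

From the compounds shown here alone, whether a carboxylic acid or a piperidine ring at the end of the chain on this oxygen would give a step beyond the scatter remains open. So does the effect of any change elsewhere on the shared core.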